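Methoxy added beside the sulfonamide of a cyclopropane amide

This account rests on a few compounds, and the source may have more. Where it says the series, first, only, none or still open, it means among the compounds named here.

Compound 1 `Cc1ccc(CC(CNC(=O)C2(c3ccc(NS(C)(=O)=O)cc3)CC2)COC(=O)C(C)(C)C)cc1C` is the weakest-looking member of a small set tested in a functional assay on CHO cells for antagonist activity at transient receptor potential cation channel subfamily V member 1 (Rattus norvegicus) (on this read-out higher numbers stand for weaker inhibition and lower numbers for stronger inhibition), where compound 1 gives 197 nM. Compound 2 `COc1cc(C(C)(C)C(=O)NCC(COC(=O)C(C)(C)C)Cc2ccc(C)c(C)c2)ccc1NS(C)(=O)=O` gives 133 nM in this assay, a number within the scatter of compound 1, while compound 3 `CC(C(=O)NCC(COC(=O)C(C)(C)C)Cc1ccc(C(C)(C)C)cc1)c1ccc(NS(C)(=O)=O)cc1` gives 52 nM, a gap beyond the scatter. The next compound, compound 4 `COc1cc(C2(C(=O)NCC(COC(=O)C(C)(C)C)Cc3ccc(C)c(C)c3)CC2)ccc1NS(C)(=O)=O`, keeps the core of compound 1 and introduces one change: methoxy in place of hydrogen on an aromatic carbon. Among the measured compounds shown here, no measured pair shows this change alone; the values of compound 1 and compound 2, which carry a methoxy group at the same place on a different amide, sit within the scatter of each other. He therefore expects a step of a 1.5-fold lower number from compound 1 to compound 4 (0.18 log units; within the scatter) that does not exceed the scatter. Compound 4 is estimated at 130 nM, within 55 nM to 310 nM.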

Compound 4, inhibition constant: 118 nM
Estimate against measurement, compound 4: 1.1-fold (0.04 log units) above; measured number inside the range.
By their numbers in this assay, from the lowest: compound 3; then compounds 4, 2 and 1 (each within the scatter of the next).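

Methoxy in place of hydrogen, ortho to a methanesulfonamido group, now stands as the single change on the core of compound 1, and in this assay it gives a 1.7-fold lower number from compound 1 to compound 4 (0.22 log units; within the scatter). At this position, then, the methoxy group is accommodated with no shift that can be told from the scatter. Nothing measured here explains this result. On these data alone, whether an ethoxy group, a hydroxyl group or a chlorine atom at the same position would move the number beyond the scatter stays open. So does whether methoxy would act alike on the amide of compound 3.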